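Propyl to cyclopropylcarbamoyl on the shared core

The source may report more compounds than this note shows. Statements on the series, on what has been measured and on what is new or still open speak of the compounds shown alone.

Compound 1 `CCCNc1nc2ccc(-c3cnc(Cl)c(NS(=O)(=O)c4ccc(F)cc4)c3)cc2s1` carries a propyl group on the ring nitrogen of the shared core. In a functional assay on U-87MG ATCC cells for antiproliferative activity against U-87 MG (Homo sapiens), read by MTT assay, with a stated time of 72 h (a higher number here means a weaker inhibitor, a lower number a stronger inhibitor), compound 1 gives "not determined" (no result reported), so it stands on no number of its own. Among the compounds with values here, the only measured member of the series is compound 2 `CNC(=O)Nc1nc2ccc(-c3cnc(OC)c(NS(=O)(=O)c4ccc(F)cc4)c3)cc2s1`, which differs from compound 1 in more than one place; in this assay compound 2 gives 1230 nM. Compound 3 `O=C(Nc1nc2ccc(-c3cnc(Cl)c(NS(=O)(=O)c4ccc(F)cc4)c3)cc2s1)NC1CC1` is the direct relative of compound 1: the change is cyclopropylcarbamoyl in place of propyl on a nitrogen on an aromatic ring. Within the data shown here, with compound 1 unmeasured, no step between measured compounds exists to size this change, and its direction in this assay cannot be read from the series. The nearest anchor is compound 2, which shares the carbamoyl-type substituent on the ring nitrogen. Compound 3 is therefore expected to land close to that anchor, estimated at 1000 nM, within a range of 250 nM to 4000 nM.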

Compound 3, half-maximal inhibitory concentration: 1720 nM
The estimate for compound 3 lay 1.7-fold (0.24 log units) below the measured number, and the stated range covers the measured number.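

No new step can be read: in this assay compound 1 gives "not determined" (no result reported) and compound 2 differs from compound 3 in more than one place. No supporting data bear on a cause. The compounds shown leave open how far cyclopropylcarbamoyl in place of propyl alone shifts the value.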